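The compounds below may be only part of what the source reports. "The series", "measured", "known", "first", "only" and "open" are said of these compounds alone.

In a functional assay on DU-145 cells (Homo sapiens) for cytotoxicity, read by ELISA, with a stated time of 4 days (on this read-out higher numbers stand for weaker inhibition and lower numbers for stronger inhibition), compound 1 `Clc1ccc(-c2cc(-c3ccoc3)cc(-c3ccco3)n2)s1` gives 17200 nM and compound 2 `Cc1ccc(-c2cc(-c3ccoc3)cc(-c3ccc(Cl)s3)n2)o1` gives 33400 nM, so these two values lie within the scatter of each other. Compound 3 `Cc1ccccc1-c1cc(-c2ccoc2)cc(-c2ccc(Cl)s2)n1` differs from compound 2 by 2-methylphenyl in place of 5-methylfuran-2-yl on an aromatic carbon, next to the ring nitrogen. Among the measured compounds shown here, the only measured step, a 1.9-fold higher number from compound 1 to compound 2 (0.29 log units; within the scatter), involves a methyl group and not a whole ring, so it bears on this change only weakly. With no measured ring exchange to suggest a larger effect, the expected change is a 1.3-fold lower number from compound 2 to compound 3 (0.13 log units; within the scatter), which means no clear shift beyond the scatter. Compound 3 is expected at 25000 nM, with an estimated range of 8000 nM to 70000 nM.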

Compound 3, half-maximal inhibitory concentration: 18500 nM
Beside the measured number, compound 3's estimate is 1.4-fold (0.13 log units) above it, and the stated range covers the measured number.
By their numbers in this assay, from the lowest: compounds 1, 3 and 2 (each within the scatter of the next).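

In this assay, replacing a five-membered ring with a larger six-membered carbon ring at the position next to the ring nitrogen gives a 1.8-fold lower number from compound 2 to compound 3 (0.26 log units; within the scatter). The exchange from furan-2-yl to 2-methylphenyl gives a 1.1-fold higher number from compound 1 to compound 3 (0.03 log units; within the scatter), so in these compounds, neither whole-ring exchange moves the number beyond the scatter. No supporting measurement is available to explain this result.

Going by these compounds, whether any group at this position can shift the number beyond the scatter remains open. An amine or a carboxylic acid there would test this with a very different kind of group.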